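Trifluoromethoxy in Place of Hydrogen and Vero Cell Cytotoxicity

The compounds below may be only part of what the source reports. "The series", "measured", "known", "first", "only" and "open" are said of these compounds alone.

Compound 1 `O=[N+]([O-])c1cn2c(n1)OC[C@@H](OCc1ccc(-c3ccc(OC(F)(F)F)cc3)cc1)C2` is the reference point of this series. In an ADME assay on Vero cells (Chlorocebus sabaeus) for cytotoxicity, with a stated time of 72 h (on this read-out lower numbers stand for stronger inhibition and higher numbers for weaker inhibition), compound 1 reaches only the limit of the assay, > 128000 nM, so no number is known for it. Compound 2 `O=[N+]([O-])c1cn2c(n1)OC[C@@H](OCc1ccc(-c3ccc(OC(F)(F)F)cc3)c(Cl)c1)C2` carries chloro in place of hydrogen on an aromatic carbon. In this assay compound 2 likewise stops at a limit, > 128000 nM. Compound 3 `O=[N+]([O-])c1cn2c(n1)OC[C@@H](OCc1ccc(-c3ccc(OC(F)(F)F)cc3)c(F)c1)C2` carries fluoro in place of hydrogen on an aromatic carbon. In this assay compound 3 also sits at a limit, > 128000 nM. The steps a step that the two limits leave unreadable from compound 1 to compound 2, a step that the two limits leave unreadable from compound 1 to compound 3 and a step that the two limits leave unreadable from compound 2 to compound 3 therefore have no readable size, because of the limit of > 128000 nM in this assay, at which 3 of the 3 values shown sit.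

Compound 4 `O=[N+]([O-])c1cn2c(n1)OC[C@@H](OCc1ccc(-c3ccc(OC(F)(F)F)cc3)cc1OC(F)(F)F)C2` differs from compound 1 by trifluoromethoxy in place of hydrogen on an aromatic carbon. The measured steps that bear on this change are the two in which hydrogen on an aromatic carbon gave way to chloro or to fluoro, and neither yielded a number, only a limit at both ends. There is thus no measured basis for a step beyond the scatter in either direction in this assay. Compound 4 is expected to stay at the limit as well, with an estimated 128000 nM and a range from 64000 nM to 256000 nM. The expected step is a number no higher from compound 1 to compound 4 (the limit leaves the size open).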

Compound 4, half-maximal inhibitory concentration: > 128000 nM
Compound 4: no number, only a limit; the forecaster's own chance of this, stated with the estimate: 85%; the middle value sits exactly at the limit.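

In this assay compound 4 gives > 128000 nM, which is a limit and not a number. The change from compound 1 to compound 4 therefore yields no readable step, because both compounds stop at a limit: the limit of > 128000 nM in this assay, at which 4 of the 4 values shown sit. Going by these compounds, whether the four compounds differ at all in this assay remains open, as does the concentration at which any of them would reach half-maximal inhibition.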